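A methyl group on the phenyl of compound 2

The compounds below may be only part of what the source reports. "The series", "measured", "known", "first", "only" and "open" are said of these compounds alone.

Going by the values given here, in a functional assay on MDA-MB-231 cells (Homo sapiens) for antiproliferative activity, read by sulforhodamine B assay, with a stated time of 48 h (a higher number here means a weaker inhibitor of growth, a lower number a stronger inhibitor of growth), only two compounds have numbers so far. Compound 1 `Cc1cc2c(cc1C)C(Cl)=C(c1n[nH]c(=S)o1)CCC2` gives 918 nM. Compound 2 `ClC1=C(c2nnc(-c3ccccc3)o2)CCCc2ccccc21` gives 1970 nM, the higher of the two numbers and so the weaker inhibitor of growth, and its gap to compound 1 lies beyond the usual scatter. Compound 3 `Cc1ccc(-c2nnc(C3=C(Cl)c4ccccc4CCC3)o2)cc1` has not yet been measured. It differs from compound 2 by methyl in place of hydrogen on an aromatic carbon, which turns phenyl to 4-methylphenyl (methyl in place of hydrogen on an aromatic carbon). Among the compounds with values here, no measured pair shows the effect of such a change, so the data offer no direct guide. In this assay no step beyond the scatter is expected, and the estimated step is a 1.1-fold lower number from compound 2 to compound 3 (0.04 log units; within the scatter). For compound 3 the expected value is 1800 nM, with an estimated range from 700 nM to 4500 nM.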

Compound 3, concentration for 50% growth inhibition: 1400 nM
For compound 3 the middle estimate is 1.3-fold (0.11 log units) above the measured one; low and high end bracket the measured number.
By their numbers in this assay, from the lowest: compounds 1, 3 and 2 (each within the scatter of the next, the first and the last beyond it).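

In this assay, going by these compounds alone, the pair gives the first reading of a change on this phenyl: a 1.4-fold lower number from compound 2 to compound 3 (0.15 log units; within the scatter). Phenyl to 4-methylphenyl, with methyl in place of hydrogen on an aromatic carbon para to a large group, therefore gives no step beyond the scatter, and compound 2 and compound 3 cannot be told apart in this read-out. Nothing measured alongside these compounds bears on the reason for this result.

On these data alone, whether a different group at this place, such as an amine, a carboxylic acid or a longer chain, would give a step beyond the scatter remains open. The compounds shown also leave open whether methyl on another carbon of the phenyl would behave as it does here.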